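A few compounds are considered here, and "the series" means these few. Any claim that something is new, unique, unknown or untested is made for them only; others in the source may bear on it.

Measured so far:

- compound 1, `COc1cccc(N2CCN(C(=O)c3oc(C)nc3-c3ccccc3F)CC2)c1`: 56.1 nM
- compound 2, `COc1cccc(N2CCN(C(=O)c3oc(C)nc3-c3ccc(F)cc3)CC2)c1`: 112 nM
- compound 3, `CCc1nc(-c2ccc(F)cc2)c(C(=O)N2CCN(c3cccc(OC)c3)CC2)o1`: 411 nM

All three share the same core and were tested in a functional assay on HL-60 cells (Homo sapiens) for inhibition, read by MTT assay, with a stated time of 72 h; on this read-out higher numbers stand for weaker inhibition and lower numbers for stronger inhibition. Compound 2 and compound 1 differ by one exchange, (2-fluorophenyl in place of 4-fluorophenyl on an aromatic carbon), and that exchange gave a 2.0-fold lower number from compound 2 to compound 1 (0.30 log units; within the scatter). Compound 3 differs from compound 2 by a second, separate exchange, (methyl in place of hydrogen on a saturated chain carbon bound to an aromatic carbon), and that one gave a 3.7-fold higher number from compound 2 to compound 3 (0.56 log units; beyond the scatter), leaving compound 3 with the highest number of the three.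

Compound 4, `CCc1nc(-c2ccccc2F)c(C(=O)N2CCN(c3cccc(OC)c3)CC2)o1`, has not yet been measured. It stands to compound 3 as compound 1 stands to compound 2: the difference is 2-fluorophenyl in place of 4-fluorophenyl on an aromatic carbon. Within the data shown here, this is the same kind of change as the one from compound 2 to compound 1, not the same change, since the surroundings differ: in compound 2 the place is two ring bonds from the ring atom that bears a methyl group (1 heavy atom), while in compound 3 it is two ring bonds from the ring atom that bears an ethyl group (2 heavy atoms).

Among the measured compounds shown here, with only one earlier example of this exchange, the expectation rests on that single step. Compound 4 is expected to move from compound 3 by about a 2.0-fold lower number from compound 3 to compound 4 (0.29 log units; within the scatter), which rests on a 2.0-fold lower number from compound 2 to compound 1 (0.30 log units; within the scatter). The estimated value for compound 4 in this assay is 210 nM, with a likely range from 90 nM to 500 nM.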

Compound 4, half-maximal inhibitory concentration: 607 nM
Compound 4: the middle estimate sits 2.9-fold (0.46 log units) below what was measured; the whole stated range lies below it.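

In this assay, placing 2-fluorophenyl where 4-fluorophenyl stood on the core bearing the ethyl group gave a 1.5-fold higher number from compound 3 to compound 4 (0.17 log units; within the scatter), so this step alone does not separate compound 3 from compound 4, yet the same exchange does not carry over from the methyl core as one fixed number: the same change on two cores in this assay, a 2.0-fold lower number (0.30 log units; within the scatter) from compound 2 to compound 1 and a 1.5-fold higher number (0.17 log units; within the scatter) from compound 3 to compound 4, 2.9-fold (0.47 log units) apart, beyond the scatter of two such steps The exchange of methyl for ethyl, seen on the 2-fluorophenyl compounds, gave an 11-fold higher number from compound 1 to compound 4 (1.03 log units; beyond the scatter), so the ethyl group costs more there than it does on the 4-fluorophenyl compounds: the same change on two cores in this assay, a 3.7-fold higher number (0.56 log units; beyond the scatter) from compound 2 to compound 3 and an 11-fold higher number (1.03 log units; beyond the scatter) from compound 1 to compound 4, 2.9-fold (0.47 log units) apart, beyond the scatter of two such steps Both gaps come from the same four compounds, so they are one finding seen from two sides; it suggests that the two places do not act independently, but it does not show why, or whether the same would hold on any other core.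

The compounds shown leave open how a longer chain such as propyl at the ring atom that bears the ethyl group would combine with either fluorophenyl group. They also leave open whether a plain phenyl group, with no fluorine, would follow the 2-fluorophenyl or the 4-fluorophenyl compounds.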